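Benzyl for Cyclohexyl on a Benzimidazole-Bearing Bis-Aryl Core

The source may hold more compounds than are shown below. What is called first, only, known or untested is meant among the compounds shown, and "the series" means these compounds.

Of the compounds shown here, two sharing a common core have been measured in a functional assay on MOLT-4 cells (Homo sapiens) for inhibition, read by sulforhodamine B assay, with a stated time of 48 h, tested at 10 uM; a lower number here means less inhibition, a higher number more inhibition at the concentration tested (going by the name of the read-out). Compound 1 `Cc1cccc(-c2cn3ccnc3c(-c3ccc4ncn(Cc5ccccc5)c4c3)n2)c1` gives 36.9% in this assay, and compound 2 `c1cn2cc(-c3ccc4c(c3)ncn4C3CCCCC3)nc(-c3ccc4ncn(C5CCCCC5)c4c3)c2n1` gives 56.9%. Of the two numbers, compound 2 stands higher, and its gap down to compound 1 lies beyond the usual scatter of this assay. Compound 3 `c1ccc(Cn2cnc3ccc(-c4nc(-c5ccc6c(c5)ncn6C5CCCCC5)cn5ccnc45)cc32)cc1` has not yet been measured. It differs from compound 2 in one place (benzyl in place of cyclohexyl on an aromatic nitrogen). For the measured compounds named here, no pair of measured compounds isolates this change, so its effect in this assay is unknown; the only other measured compound, compound 1, carries a benzyl too and sits lower than compound 2. A modest step downward from compound 2 is therefore expected, a number 10.9 percentage points lower from compound 2 to compound 3 (beyond the scatter), though one within or near the scatter would not surprise. Compound 3 is estimated to give 46%, with a range from 26% to 66%.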

Compound 3, a percentage reported as inhibition, at one concentration (the size of the read-out at that concentration, not a potency): 95.6%
Estimate against measurement, compound 3: 49.6 percentage points below; measured number above the stated range.
By their numbers in this assay, from the lowest: compound 1; then compound 2; then compound 3.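

In this assay, replacing cyclohexyl with benzyl on this aromatic nitrogen gives a number 38.7 percentage points higher from compound 2 to compound 3 (beyond the scatter), which shows that the read-out at this position is highly sensitive to the group it carries. Both groups consist of carbon only and have no hydrogen-bond donors, hydrogen-bond acceptors or net charge, so a large step can occur without any change in those counts. No measurement shown here accounts for the size of this step.

The compounds shown leave open whether the aromatic ring or its connection to the nitrogen matters more, a question that phenyl attached directly to the nitrogen or a longer phenethyl chain would address. They also leave open whether benzyl in place of the remaining cyclohexyl would change the read-out, or how a benzyl bearing an amine would behave.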